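Swapping a Saturated Ring for a Branched Aromatic Side Chain

The source may hold more compounds than are shown below. What is called first, only, known or untested is meant among the compounds shown, and "the series" means these compounds.

Measured compounds:
compound 1 `O=C(CCc1nc2cccnc2n1Cc1ccccc1)NCc1ccc(F)cc1` gives 23.9 mL/min
compound 2 `O=C(CCc1nc2cccnc2n1Cc1ccccc1)NCC1CCCCC1` gives 30.8 mL/min

Both numbers come from an ADME assay on liver (Mus musculus, strain CD1) for metabolic stability, read by HPLC, using microsomes and NADPH, with a stated time of 45 min, tested at 1 uM; a lower number here means slower removal, a higher number faster removal of the compound. Among the two numbers, compound 2 stands highest, with compound 1 nearest; the step of a 1.3-fold higher number from compound 1 to compound 2 (0.11 log units; within the scatter) lies within the scatter, so the two compounds cannot be told apart on this measure.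

Compound 3 `C[C@H](NC(=O)CCc1nc2cccnc2n1Cc1ccccc1)c1ccccc1` has not yet been measured. Compared with compound 2 the change is 1-phenylethyl in place of cyclohexylmethyl on an amide-type nitrogen.

Within the data shown here, the only measured step that bears on this change is the one from compound 1 to compound 2, where a saturated ring replaced an aromatic ring on the same part of the molecule and the number moved only within the scatter a 1.3-fold higher number from compound 1 to compound 2 (0.11 log units; within the scatter). Returning to an aromatic ring, now with a defined stereocentre added, is therefore expected to give at most a small step, a 1.2-fold lower number from compound 2 to compound 3 (0.09 log units; within the scatter), in this assay. The estimate for compound 3 is 25 mL/min, with a range from 12 mL/min to 50 mL/min.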

Compound 3, intrinsic clearance in a liver preparation (reported as CLH), per the amount of preparation that the assay uses: 21.4 mL/min
Compound 3: middle estimate off by 1.2-fold (0.07 log units), on the high side; the measured number falls inside the stated range.
By their numbers in this assay, from the lowest: compounds 3, 1 and 2 (each within the scatter of the next).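

In this assay, the change on the amide-type nitrogen gives a 1.4-fold lower number from compound 2 to compound 3 (0.16 log units; within the scatter), and replacing 4-fluorobenzyl with 1-phenylethyl gives a 1.1-fold lower number from compound 1 to compound 3 (0.05 log units; within the scatter). With all three compounds now within the scatter of one another, this measure separates neither the aromatic rings from the saturated ring nor the compound with a defined stereocentre from those without one. No available evidence speaks to the reason for this result.

The compounds shown leave open whether the mirror-image form of 1-phenylethyl would read the same. They also leave open whether a group of another kind on the amide-type nitrogen, such as an amine or a carboxylic acid, would produce a step beyond the scatter.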